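The source may hold more compounds than are shown below. What is called first, only, known or untested is meant among the compounds shown, and "the series" means these compounds.

In a functional assay on M21 cells (Homo sapiens) for inhibition, read by sulforhodamine B assay, with a stated time of 48 h (a higher number here means a weaker inhibitor of growth, a lower number a stronger inhibitor of growth), compound 1 `c1cc(OC2CCCCCC2)ccc1NC1=NCCO1` gives 27100 nM and compound 2 `c1cc(NC2=NCCO2)cc(OC2CCCCCC2)c1` gives 14400 nM, two values within the scatter of each other. Compound 3 `O=C(CCl)NC(=O)Nc1ccc(C2CCCCC2)cc1` at 900 nM lies lower than compound 2 by more than the scatter, so compound 2 stands with compound 1 at the high end of the three numbers. Compound 4 `O=C(CCl)NC(=O)Nc1cccc(OC2CCCCCC2)c1` differs from compound 2 by a group of 7 heavy atoms (3 carbon, 1 nitrogen, 2 oxygen, 1 chlorine; no ring) in place of a group of 5 heavy atoms (3 carbon, 1 nitrogen, 1 oxygen; one five-membered non-aromatic ring with 2 hetero atoms), on a nitrogen on an aromatic ring and nothing else. Going by the values given here, no measured pair shows this change alone. The expectation rests on compound 3 at 900 nM as the one measured carrier of the ((chloromethyl)carbonyl)carbamoyl group, on a different remainder. A fall in this assay beyond the scatter is expected, estimated as a 5.8-fold lower number from compound 2 to compound 4 (0.76 log units; beyond the scatter) toward a lower number. Compound 4 is expected at 2500 nM within an estimated range from 800 nM to 8000 nM for now.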

Compound 4, concentration for 50% growth inhibition: 4200 nM
For compound 4 the middle estimate is 1.7-fold (0.23 log units) below the measured one; the measured number falls inside the stated range.
By their numbers in this assay, from the lowest: compound 3; then compound 4; then compounds 2 and 1 (each within the scatter of the next).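

In this assay, ((chloromethyl)carbonyl)carbamoyl in place of the five-membered non-aromatic ring with 2 hetero atoms, on a nitrogen on an aromatic ring, gives a 3.4-fold lower number from compound 2 to compound 4 (0.54 log units; beyond the scatter). Going by these compounds alone, this is the first comparison that isolates one change, and it shows a modest gain with the rest of the structure held constant. Nothing available accounts for this step. 

On these data alone, whether the chlorine is needed remains open; an acetylcarbamoyl group, with hydrogen in place of that chlorine, on the core of compound 4 would test this. Also open, as far as these compounds go, is whether the same exchange gives a similar step on the core of compound 1.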